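The compounds below may be only part of what the source reports. "The series", "measured", "known", "first", "only" and "open" are said of these compounds alone.

In a functional assay on K562 cells (Homo sapiens) for antiproliferative activity, read by sulforhodamine B assay, with a stated time of 72 h (on this read-out lower numbers stand for stronger inhibition and higher numbers for weaker inhibition), compound 1 `O=S(=O)(Nc1ccccn1)c1ccc(Nc2nncc3ccccc23)cc1` gives 34 nM, and compound 2 `NS(=O)(=O)c1ccc(Nc2nncc3ccccc23)cc1` gives 14 nM. Within the data shown here, the single measured step, a 2.4-fold lower number from compound 1 to compound 2 (0.39 log units; beyond the scatter), runs between them. Among the measured compounds shown here, compound 2 thus holds the lowest of the two numbers so far, with compound 1 as its only neighbour at a higher number.

Compound 3 `Fc1ccc(Nc2nncc3ccccc23)cc1` differs from compound 2 in one place: fluoro in place of sulfamoyl on an aromatic carbon. For the measured compounds named here, only the step from compound 1 to compound 2 bears on this change, and only loosely, since it altered what sat on the sulfonamide nitrogen while the sulfonamide itself stayed; here the whole group leaves and a single fluorine enters on the aromatic carbon, para to the large group. That step was modest and favoured the smaller group, but nothing measured shows what happens when the sulfonamide is gone altogether. The account therefore expects compound 3 to give a higher number than compound 2, by a step estimated at an 11-fold higher number from compound 2 to compound 3 (1.03 log units; beyond the scatter), with wide uncertainty. Compound 3 is estimated at 150 nM in this assay, within a range of 30 nM to 800 nM.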

Compound 3, half-maximal inhibitory concentration: 6.7 nM
The estimate for compound 3 lay 22-fold (1.35 log units) above the measured number, outside the stated range (below it).
By their numbers in this assay, from the lowest: compound 3; then compound 2; then compound 1.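

In this assay, putting fluoro in place of sulfamoyl on the aromatic carbon para to a large group gives a 2.1-fold lower number from compound 2 to compound 3 (0.32 log units; beyond the scatter), so a low number at this position does not depend on keeping the sulfonamide. The earlier step changed only what sat on the sulfonamide nitrogen and left the sulfamoyl framework in place, whereas this one removes the whole group, including its hydrogen-bond donor and acceptors as counted, and the number still moves down, modestly but beyond the scatter. No measured evidence on hand explains why this exchange lowers the number, and the change is documented by this single pair of compounds.

The compounds shown leave open whether the low number is particular to fluoro or would also appear with hydrogen, chloro, methoxy, a nitrile, an amine or a carboxylic acid on the same aromatic carbon. They also leave open whether the same exchange would give a step of similar size on a different core, or with fluoro at another place on this ring.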